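A few compounds are considered here, and "the series" means these few. Any claim that something is new, unique, unknown or untested is made for them only; others in the source may bear on it.

Compound 1, `Cc1ccccc1-c1cc(C#Cc2ccc(CCC(=O)O)cc2)ccn1`, gives 92% in an in vitro functional assay on 1321-N1 cells for agonist activity at Free fatty acid receptor 1 (Homo sapiens), read by fluorescence, spectrophotometry and calcium flux; a higher number here means a larger maximal response, a lower number a smaller maximal response.
Compound 2, `O=C(O)CCc1ccc(C#Cc2ccnc(-c3ccccc3)c2)cc1`, gives 97% in this assay.
Compound 3, `COc1cc(C#Cc2ccc(CCC(=O)O)cc2)ccn1`, gives 98% in this assay.

Compound 3 carries the largest of the three numbers, but the gaps are a number 1 percentage points higher from compound 2 to compound 3 (within the scatter) and a number 6 percentage points higher from compound 1 to compound 3 (within the scatter), both within the scatter, so the three compounds cannot be told apart on maximal response. Compound 4, `Cc1cc(C#Cc2ccc(CCC(=O)O)cc2)ccn1`, has not yet been measured in this assay. It differs from compound 3 by methyl in place of methoxy on an aromatic carbon.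

Every measured step sits at this same aromatic carbon of the shared core: a number 5 percentage points higher from compound 1 to compound 2 (within the scatter), a number 6 percentage points higher from compound 1 to compound 3 (within the scatter) and a number 1 percentage points higher from compound 2 to compound 3 (within the scatter). Groups as different as hydrogen, methyl, methoxy, phenyl and 2-methylphenyl there all leave the maximal response in this assay unchanged beyond the scatter. Among the measured compounds shown here, no measured pair shows methyl against methoxy directly, so the expectation rests on this tolerance alone. An estimated step of a number 3 percentage points lower from compound 3 to compound 4 (within the scatter) follows, with no change beyond the scatter expected. Compound 4 is therefore estimated at 95% in this assay, between 82% and 105%.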

Compound 4, largest response reached (reported as efficacy), in percent of the reference or control that the assay uses: 102%
Compound 4: middle estimate off by 7 percentage points, on the low side; measured number inside the range.
By their numbers in this assay, from the lowest: compounds 1, 2, 3 and 4 (each within the scatter of the next).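

Among the compounds shown here, the first direct comparison of methyl with methoxy at this aromatic carbon next to the ring nitrogen gives a number 4 percentage points higher from compound 3 to compound 4 (within the scatter) in this assay and so shows that the swap leaves the maximal response unchanged beyond the scatter, even with the hydrogen-bond acceptor of the methoxy gone. The small methyl also holds up against the two larger ring-bearing groups, with a number 5 percentage points higher from compound 2 to compound 4 (within the scatter) for methyl in place of phenyl and a number 10 percentage points higher from compound 1 to compound 4 (within the scatter) for methyl in place of 2-methylphenyl, so none of these groups can be told apart at this position on maximal response. No measurement shown explains this tolerance.

Only methyl, methoxy, phenyl and 2-methylphenyl are shown at this carbon, so it remains open whether an amine, a carboxylic acid or a longer chain there would keep the same maximal response. These compounds also speak only to the largest response reached, not to how much compound is needed to reach it.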